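Replacing bromine with a phenol on the shared core

A few compounds are considered here, and "the series" means these few. Any claim that something is new, unique, unknown or untested is made for them only; others in the source may bear on it.

Compound 1 `Cc1cc(NCc2ccccn2)n2ncc(Br)c2n1` was studied in a physicochemical assay for solubility, read by HPLC, using the shake flask method, measured as kinetic solubility, with a stated time of 2 h, at pH 7.4 (on this read-out lower numbers stand for lower solubility and higher numbers for higher solubility), and gave 89300 nM, the highest of the two numbers in hand. Compound 2 `Cc1cc(OCc2ccccn2)n2nc(C)c(-c3ccccc3)c2n1` gave 25600 nM in this assay, a lower number that lies beyond the usual scatter. Compound 3 `Cc1cccc(CNc2cc(C)nc3c(-c4ccccc4)c(C)nn23)n1` reached only a limit of this assay, < 5000 nM; one of the three values sits at that limit (the limit of < 5000 nM in this assay, at which 1 of the 3 values shown sits).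

The step from compound 1 to compound 4 `Cc1cc(NCc2ccccn2)n2ncc(-c3ccc(O)cc3)c2n1` puts (4-hydroxyphenyl in place of bromo on an aromatic carbon). Among the compounds with values here, no measured pair isolates such a change, so the expectation rests on the numbers above: compounds 2 and 3, both carrying a phenyl on the core, sit well below compound 1. For compound 4 a step of a 4.5-fold lower number from compound 1 to compound 4 (0.65 log units; beyond the scatter) downward is expected, giving an estimated solubility of 20000 nM, between 5000 nM and 60000 nM.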

Compound 4, solubility: 10900 nM
For compound 4 the middle estimate is 1.8-fold (0.26 log units) above the measured one; the range from low to high includes it.
By their numbers in this assay, from the lowest: compound 4; then compound 2; then compound 1. At a limit, below all of these: compound 3.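

In this assay, 4-hydroxyphenyl in place of bromo on this aromatic carbon gives an 8.2-fold lower number from compound 1 to compound 4 (0.91 log units; beyond the scatter) and is the first step shown that isolates a single change on the shared core. It shows that the number responds to the group at this place, and that it falls even though the entering group adds a hydrogen-bond donor and a hydrogen-bond acceptor. Nothing measured here accounts for the step. The compounds shown leave open whether an amine or a carboxylic acid on this phenyl ring would give a different number, and how an unsubstituted phenyl would compare at this carbon with nothing else changed.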